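The source may report more compounds than this note shows. Statements on the series, on what has been measured and on what is new or still open speak of the compounds shown alone.

Measured in a physicochemical assay, read by spectrophotometry, with a stated time of 30 min; on this read-out lower numbers stand for stronger inhibition and higher numbers for weaker inhibition:
- compound 1 `COc1cc(/C=N/NC(=O)CCCc2nc3ccccc3c(=O)[nH]2)cc(OC)c1OC` gives 106000000 nM
- compound 2 `COc1cc(/C=N/NC(=O)CCCc2nc3ccccc3c(=O)[nH]2)ccc1O` gives 236000000 nM

Compound 2, at 236000000 nM, holds the higher of the two numbers in this assay and so is the weaker inhibitor of the pair. Its gap to compound 1 lies beyond the usual scatter. The next compound is compound 3 `COc1cc(/C=N/NC(=O)CCCc2nc3ccccc3c(=O)[nH]2)cc(OC)c1O`, which has not yet been measured. It comes from compound 2 by one change, methoxy in place of hydrogen on an aromatic carbon, ortho to a hydroxy group.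

Going by the values given here, no measured step shows this change, so its effect cannot be read directly from the data. Among the compounds with values here, the only guide is the pair of values, and with just two compounds no trend can be claimed. A modest move towards a lower number in this assay is expected, possibly not much beyond the scatter. The estimated change is a 1.7-fold lower number from compound 2 to compound 3 (0.23 log units; within the scatter). For compound 3 the expected value is 140000000 nM, with an estimated range from 55000000 nM to 320000000 nM.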

Compound 3, half-maximal inhibitory concentration: 97000000 nM
Beside the measured number, compound 3's estimate is 1.4-fold (0.16 log units) above it; low and high end bracket the measured number.
By their numbers in this assay, from the lowest: compounds 3 and 1 (each within the scatter of the next); then compound 2.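

In this assay, going by these compounds alone, methoxy in place of hydrogen on the aromatic carbon ortho to a hydroxy group gives a 2.4-fold lower number from compound 2 to compound 3 (0.39 log units; beyond the scatter) and is the first reading of this position, a modest step that lies beyond the scatter. Hydrogen in place of methyl on an oxygen on the aromatic ring gives a 1.1-fold lower number from compound 1 to compound 3 (0.04 log units; within the scatter) and so leaves compound 1 and compound 3 within the scatter of each other; in this pair, the read-out does not separate the hydroxy group from a third methoxy group. Nothing at hand gives a reason for either step.

With methoxy as the only group shown on this aromatic carbon, it remains open whether an amine, a fluorine atom or a longer ethoxy group there would also give a lower number than compound 2. Also open, on these data alone, is how a carboxylic acid in place of the hydroxy group of compound 3 would read in this assay.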